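A few compounds are considered here, and "the series" means these few. Any claim that something is new, unique, unknown or untested is made for them only; others in the source may bear on it.

Measured compounds in the series:

compound 1 `N=C(S)CCCCCn1nc(-c2ccccc2)ccc1=O`: 10.2 mg/kg
compound 2 `N=C(S)CCCCCCN1N=C(c2ccccc2)CCC1=O`: 23 mg/kg
compound 3 `C/N=C(\S)C(C)Cn1ncccc1=O`: a limit only, > 50 mg/kg

In a functional assay on the whole organism (stomach) for inhibition, with Rattus norvegicus as the target (a higher number here means that more compound is needed for the effect, a lower number that less compound is needed), compound 1 gives 10.2 mg/kg and so has the lowest of the two numbers shown. Compound 2 gives 23 mg/kg, a higher number, and the gap to compound 1 lies beyond the scatter of the assay. Compound 3 stands at the limit of > 50 mg/kg in this assay, at which 1 of the 3 values shown sits, so for it the assay reports no number; compound 3 also differs from compound 1 at more than one place, so its limit says nothing direct about any single change.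

Compound 4 `C/N=C(/S)CCCCCn1nc(-c2ccccc2)ccc1=O` has not been measured. It differs from compound 1 in one place:

a group of 4 heavy atoms (2 carbon, 1 nitrogen, 1 sulfur; no ring) in place of a group of 3 heavy atoms (1 carbon, 1 nitrogen, 1 sulfur; no ring), on a saturated chain carbon, five bonds along the chain from an aromatic nitrogen

Within the data shown here, no step between two measured compounds isolates this change, so the size of the effect in this assay can only be guessed. The expectation for compound 4 is a somewhat higher number than for compound 1, a step of a 2.0-fold higher number from compound 1 to compound 4 (0.29 log units; within the scatter), around the edge of the scatter; the estimate for compound 4 is 20 mg/kg, with a likely range from 7 mg/kg to 60 mg/kg, and some chance that the assay returns only a limit.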

Compound 4, dose for half-maximal effect: 18.3 mg/kg
Beside the measured number, compound 4's estimate is 1.1-fold (0.04 log units) above it; measured number inside the range.
By their numbers in this assay, from the lowest: compounds 1, 4 and 2 (each within the scatter of the next, the first and the last beyond it). At a limit, above all of these: compound 3.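

Notes on the series: in this assay, the single step at this position reads a 1.8-fold higher number from compound 1 to compound 4 (0.25 log units; within the scatter), so the group of 4 heavy atoms in place of the group of 3 heavy atoms does not shift the dose beyond what repeat measurements would give. The earlier compounds shown here differed from each other in more than one place and isolated nothing here, whereas this pair shows that the position, on a saturated chain carbon, five bonds along the chain from an aromatic nitrogen, keeps the effect in the whole animal when 1 hydrogen-bond donor stands in place of 2 hydrogen-bond donors. Nothing shown accounts for the size of this step.

Still open, going by these compounds, is whether a larger or charged group at this place, such as a benzyl group or a carboxylic acid, would move the number beyond the scatter. Among these compounds, also open is whether the same change holds on the core of compound 2, and whether a longer chain than the one in compound 1 would alter the result.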